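This account rests on a few compounds, and the source may have more. Where it says the series, first, only, none or still open, it means among the compounds named here.

Measured compounds:
compound 1 `CN1CCN(CCCCOc2cc(C(=O)N3CCCCc4sccc43)ccc2NC(=O)c2ccccc2-c2ccccc2)CC1`, which in an assay on adrenal medulla for inhibition of Vasopressin V2 receptor (Rattus norvegicus), read by radioligand binding (a higher number here means a weaker inhibitor, a lower number a stronger inhibitor), gives 7 nM;
compound 2 `CN(C)C1CCN(C(=O)COc2cc(C(=O)N3CCCCc4sccc43)ccc2NC(=O)c2ccccc2-c2ccccc2)CC1`, which in this assay gives 4 nM.

For the measured compounds named here, compound 2 holds the lowest of the two numbers so far, but its nearest neighbour is compound 1, and the step of a 1.8-fold lower number from compound 1 to compound 2 (0.24 log units; within the scatter) stays within the scatter, so the two cannot be set apart on these data. Compound 3 `CN1CCCN(CCCOc2cc(C(=O)N3CCCCc4sccc43)ccc2NC(=O)c2ccccc2-c2ccccc2)CC1` is the next variation on the shared core. Relative to compound 2 it carries 2-(4-methyl-1,4-diazepan-1-yl)ethyl in place of (4-(dimethylamino)piperidin-1-yl)carbonyl on a saturated chain carbon bound to an oxygen on an aromatic ring. Going by the values given here, only one measured step bears on this change: the one from compound 1 to compound 2, a 1.8-fold lower number from compound 1 to compound 2 (0.24 log units; within the scatter), in which one amine-bearing chain on the ether oxygen was exchanged for another without moving the number beyond the scatter. Among the compounds with values here, compound 3 again swaps one such chain for another, and since the single comparable exchange left the number essentially where it was, the step of a 1.5-fold higher number from compound 2 to compound 3 (0.18 log units; within the scatter) is expected to stay within the scatter as well. For compound 3 in this assay the estimate is therefore 6 nM, with a likely range from 2.5 nM to 15 nM.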

Compound 3, half-maximal inhibitory concentration: < 1 nM
Compound 3: only a limit was reported; the forecaster's own chance of this, stated with the estimate: 2%; at least 6.0-fold (0.77 log units) between middle value and limit.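

In this assay compound 3 sits at a limit and not at a number: the limit of < 1 nM in this assay, at which 1 of the 3 values shown sits.

The place on a saturated chain carbon bound to an oxygen on an aromatic ring had so far shown no effect, since a 1.8-fold lower number from compound 1 to compound 2 (0.24 log units; within the scatter) stayed within the scatter, but it now proves able to move the number: the new chain gives an at least 4.0-fold lower number from compound 2 to compound 3 (0.60 log units; beyond the scatter), and the comparison with the other neighbour gives an at least 7.0-fold lower number from compound 1 to compound 3 (0.84 log units; beyond the scatter). Both steps lie beyond the scatter, so these amine-bearing chains are not interchangeable here, and the 3-(4-methyl-1,4-diazepan-1-yl)propyl chain of compound 3 stands apart from the chains of compound 1 and compound 2.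

As far as these compounds go, how far compound 3 lies past its limit stays open, so the true size of both steps is unknown. Each step also changes the ring and the chain together, and only a 4-methylpiperazin-1-yl ring on the shorter chain of compound 3, or a 4-methyl-1,4-diazepan-1-yl ring on the longer chain of compound 1, would show which of the two carries the step.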